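A few compounds are considered here, and "the series" means these few. Any claim that something is new, unique, unknown or untested is made for them only; others in the source may bear on it.

Three compounds of the series carry measured values. Compound 1 `COc1ccc(SCc2ccc(/C=C/C(=O)Nc3ccccc3N)cc2)cc1OC` gives 21.9% in a functional assay on HeLa cells (Homo sapiens) for inhibition, read by CCK-8 assay, with a stated time of 72 h, tested at 8 uM; on this read-out lower numbers stand for less inhibition of growth and higher numbers for more inhibition of growth at the one concentration tested. Compound 2 `Nc1ccccc1NC(=O)c1ccc(CSc2nccc(C(F)(F)F)n2)cc1` gives 83.4% in this assay, and compound 3 `Nc1ccccc1NC(=O)c1ccc(CSc2cccc(F)c2)cc1` gives 78.4% in this assay. Compound 3 thus stands second highest of the three numbers; its nearest neighbour is compound 2, within the scatter, and its furthest is compound 1, beyond the scatter. Compound 4 `Nc1ccccc1NC(=O)c1ccc(CSc2ccc(F)cc2)cc1` is not yet measured in this assay. It differs from compound 3 in one place: 4-fluorophenyl in place of 3-fluorophenyl on a sulfur. For the measured compounds named here, no step between measured compounds covers this change; the two groups have the same atoms, joined differently, and no step beyond the scatter is expected in this assay. Compound 4 is estimated at 75%, range 55% to 90%, an expected step of a number 3.4 percentage points lower from compound 3 to compound 4 (within the scatter).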

Compound 4, percent growth inhibition at one concentration: 79.3%
Compound 4: middle estimate off by 4.3 percentage points, on the low side; measured number inside the range.
By their numbers in this assay, from the lowest: compound 1; then compounds 3, 4 and 2 (each within the scatter of the next).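

The exchange of 3-fluorophenyl for 4-fluorophenyl on a sulfur gives a number 0.9 percentage points higher from compound 3 to compound 4 (within the scatter) in this assay, so the two fluorine placements cannot be told apart on this read-out. For the compounds shown here, this is the only step between measured compounds that differ in one place, and it covers these two placements alone. Nothing on hand explains this step.

Open, on these data alone, is whether an amine or a carboxylic acid in place of the fluorine would give a similar number. Also open, as far as these compounds go, is what a longer chain on the sulfur would give.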